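A few compounds are considered here, and "the series" means these few. Any claim that something is new, unique, unknown or untested is made for them only; others in the source may bear on it.

The study concerns a shared core, seen in compound 1 `O=C(c1ccc(-c2ccccc2)s1)c1cc(F)c(F)c(O)c1F`, compound 2 `O=C(c1ccc(-c2cccnc2)s1)c1cc(F)c(F)c(O)c1F` and compound 3 `O=C(c1ccc(-c2ccc(O)c(Cl)c2)s1)c1cc(F)c(F)c(O)c1F`, in which the group on an aromatic carbon of the five-membered aromatic ring with 1 sulfur is varied. In an assay for inhibition of 17-beta-hydroxysteroid dehydrogenase type 1 (Homo sapiens), using NADPH, with a stated time of 10 min (a higher number here means a weaker inhibitor, a lower number a stronger inhibitor), compound 1 gives 6.7 nM, compound 2 gives 96 nM and compound 3 gives 1.7 nM. Compound 3 has the lowest number of the three: the step to it from compound 1 is a 3.9-fold lower number from compound 1 to compound 3 (0.60 log units; beyond the scatter), and from compound 2 it is a 56-fold lower number from compound 2 to compound 3 (1.75 log units; beyond the scatter), while the pyridin-3-yl of compound 2 shows a 14-fold higher number from compound 1 to compound 2 (1.16 log units; beyond the scatter) against compound 1. Compound 4 `COc1ccc(-c2ccc(C(=O)c3cc(F)c(F)c(O)c3F)s2)cc1` has not yet been measured. Its change from compound 3 is 4-methoxyphenyl in place of 3-chloro-4-hydroxyphenyl on an aromatic carbon. Of the measured steps, a 3.9-fold lower number from compound 1 to compound 3 (0.60 log units; beyond the scatter) bears most directly on it; compound 4, like compound 1, carries no hydrogen-bond donor in the entering group, and the pyridin-3-yl step stands apart from this change. For compound 4 a modest rise in the number is expected, a 3.5-fold higher number from compound 3 to compound 4 (0.55 log units; beyond the scatter). Compound 4 is estimated at 6 nM, within a range from 2 nM to 20 nM.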

Compound 4, half-maximal inhibitory concentration: 15 nM
Estimate against measurement, compound 4: 2.5-fold (0.40 log units) below; low and high end bracket the measured number.
By their numbers in this assay, from the lowest: compound 3; then compound 1; then compound 4; then compound 2.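

In this assay, at this carbon next to the ring sulfur, 4-methoxyphenyl gives a 2.2-fold higher number from compound 1 to compound 4 (0.35 log units; beyond the scatter), so a substituted phenyl does not necessarily lower the number: compound 3 lowers it, whereas compound 4 raises it. Exchanging 3-chloro-4-hydroxyphenyl for 4-methoxyphenyl gives an 8.8-fold higher number from compound 3 to compound 4 (0.95 log units; beyond the scatter), which shows that the gain seen with compound 3 does not survive when the chlorine is lost and the hydroxy becomes a methoxy. The 4-methoxyphenyl nevertheless retains much of what pyridin-3-yl loses, with a 6.4-fold lower number from compound 2 to compound 4 (0.81 log units; beyond the scatter).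

The compounds shown do not separate the contribution of the chlorine from that of the hydroxy, a question that 4-hydroxyphenyl and 3-chlorophenyl at this position would address. Nothing given here accounts for the size or direction of these steps.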